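The source may hold more compounds than are shown below. What is called first, only, known or untested is meant among the compounds shown, and "the series" means these compounds.

Measured compounds, values in a functional assay on Hep 3B2 cells (Homo sapiens) for antiproliferative activity, read by MTT assay, with a stated time of 24 h; a higher number here means a weaker inhibitor, a lower number a stronger inhibitor:
compound 1 `CCc1ccc2nc(C(=O)Nc3c(F)cc(-c4cccc(F)c4)cc3F)c(C)c(O)c2c1`: 15800 nM
compound 2 `COc1ccc2nc(C(=O)Nc3ccc(-c4ccccc4)cc3)c(C)c(O)c2c1`: 18100 nM
compound 3 `CCc1ccc2nc(C(=O)Nc3c(F)cc(-c4cccc(F)c4)cc3F)c(C)c(C(=O)O)c2c1`: 16900 nM

Compound 3 differs from compound 1 by carboxy in place of hydroxy on an aromatic carbon, and the step is a 1.1-fold higher number from compound 1 to compound 3 (0.03 log units; within the scatter). The cores of compound 1 and compound 2 differ in more than one place; that difference is not broken down here.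

Compound 4 `COc1ccc2nc(C(=O)Nc3ccc(-c4ccccc4)cc3)c(C)c(C(=O)O)c2c1` differs from compound 2 by carboxy in place of hydroxy on an aromatic carbon. The place is the same word for word as in the change from compound 1 to compound 3, so this is the same change on the core of compound 2.

In this assay the step from compound 2 to compound 4 is expected to be a 1.0-fold higher number from compound 2 to compound 4 (0.02 log units; within the scatter), which rests on the step of a 1.1-fold higher number from compound 1 to compound 3 (0.03 log units; within the scatter) lying within the scatter. Compound 4 is therefore estimated at 19000 nM, with the expected range 9000 nM to 40000 nM.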

Compound 4, half-maximal inhibitory concentration: 9430 nM
Beside the measured number, compound 4's estimate is 2.0-fold (0.30 log units) above it; low and high end bracket the measured number.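

In this assay, carboxy in place of hydroxy on an aromatic carbon gives a 1.9-fold lower number from compound 2 to compound 4 (0.28 log units; within the scatter), and the two steps with this change agree within the scatter: the same change on two cores in this assay, a 1.1-fold higher number (0.03 log units; within the scatter) from compound 1 to compound 3 and a 1.9-fold lower number (0.28 log units; within the scatter) from compound 2 to compound 4, 2.1-fold (0.31 log units) apart, within the scatter of two such steps. Among these compounds, on these two cores, then, the change carries over as a step that cannot be told apart from no step at all, with no sign that its outcome depends on the core. Among the compounds shown here, with only two pairs, this does not show that the same would hold on other cores.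

Still open, from the compounds shown here alone, is whether a methyl ester, a primary amide or an amine in that place would give a step beyond the scatter. Also open, going by these compounds, is how the change reads outside this assay.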